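Working notes: alkynyl series, Vero cell tolerance

This account rests on a few compounds, and the source may have more. Where it says the series, first, only, none or still open, it means among the compounds named here.

Measured in an ADME assay on Vero cells (Chlorocebus sabaeus) for cytotoxicity, read by MTT assay; a higher number here means that more compound is tolerated, a lower number that less compound is tolerated:
compound 1 `CCCCC#Cc1cn([C@@H]2O[C@H](CO)[C@@H](O)[C@H]2O)c(=O)[nH]c1=O` gives 103000 nM
compound 2 `O=c1[nH]c(=O)n([C@@H]2O[C@H](CO)[C@@H](O)[C@H]2O)cc1C#CC(O)c1ccccc1` gives 65400 nM
compound 3 `O=c1[nH]c(=O)n([C@@H]2O[C@H](CO)[C@@H](O)[C@H]2O)cc1C#Cc1ccccc1` gives 78400 nM

Compound 3 sits second highest of the three numbers; its nearest neighbour is compound 2 with a 1.2-fold higher number from compound 2 to compound 3 (0.08 log units; within the scatter), its furthest is compound 1 with a 1.3-fold lower number from compound 1 to compound 3 (0.12 log units; within the scatter), both within the scatter. Compound 4 `CCCCCCC#Cc1cn([C@@H]2O[C@H](CO)[C@@H](O)[C@H]2O)c(=O)[nH]c1=O` differs from compound 3 by hexyl in place of phenyl on a triple-bonded carbon.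

Bearing on this change are a 1.3-fold lower number from compound 1 to compound 3 (0.12 log units; within the scatter) and a 1.6-fold lower number from compound 1 to compound 2 (0.20 log units; within the scatter), where a butyl chain was replaced by ring-containing groups and the numbers stayed within the scatter. The reverse direction, back to a plain chain, is therefore expected to give no step beyond the scatter in this assay. For compound 4 the expected step is a 1.1-fold higher number from compound 3 to compound 4 (0.06 log units; within the scatter), with an estimate of 90000 nM and a range from 45000 nM to 180000 nM.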

Compound 4, half-maximal cytotoxic concentration: 111000 nM
The estimate for compound 4 lay 1.2-fold (0.09 log units) below the measured number, and the stated range covers the measured number.
By their numbers in this assay, from the lowest: compounds 2, 3, 1 and 4 (each within the scatter of the next).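

In this assay, a hexyl chain and a phenyl ring on the triple-bonded carbon cannot be told apart (a 1.4-fold higher number from compound 3 to compound 4 (0.15 log units; within the scatter)), which extends the earlier picture to a chain and a ring with the same count of carbons. Hexyl and hydroxy(phenyl)methyl also read alike (a 1.7-fold higher number from compound 2 to compound 4 (0.23 log units; within the scatter)), as do hexyl and butyl (a 1.1-fold higher number from compound 1 to compound 4 (0.03 log units; within the scatter)). No measurement available here explains why these groups read alike.

On these data alone, whether an amine, a carboxylic acid or a chain longer than hexyl on the triple-bonded carbon would give a step beyond the scatter in this assay stays open.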